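Anilide series, solubility notes: compound 2 to compound 3

The source may report more compounds than this note shows. Statements on the series, on what has been measured and on what is new or still open speak of the compounds shown alone.

Measured so far:
compound 1 `COc1ccc2nc(C)cc(OC3CCN(c4ccccc4)C3=O)c2c1` gives 215000 nM
compound 2 `COc1ccc2nc(C)cc(OCC(=O)Nc3c(C)cccc3C)c2c1` gives 112000 nM

In a physicochemical assay for solubility, in phosphate buffer, measured as kinetic solubility, with a stated time of 1 h, at pH 7.4 (on this read-out higher numbers stand for higher solubility and lower numbers for lower solubility), compound 2 stands as the lower of the two numbers, though its gap to compound 1 lies within the scatter, so no order between them is claimed. Compound 3 `COc1ccc2nc(C)cc(OCC(=O)Nc3ccc(Cl)cc3)c2c1` has not yet been measured. It differs from compound 2 in one place: 4-chlorophenyl in place of 2,6-dimethylphenyl on an amide-type nitrogen. Among the compounds with values here, no measured step between compounds that differ in one place is available in this set. The step from compound 2 to compound 3 is expected to be small, a 1.4-fold lower number from compound 2 to compound 3 (0.15 log units; within the scatter), at most slightly downward and likely not beyond the scatter. Compound 3 is thus estimated at 80000 nM, with a range from 30000 nM to 200000 nM.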

Compound 3, solubility: 9000 nM
Beside the measured number, compound 3's estimate is 8.9-fold (0.95 log units) above it; measured number below the stated range.
By their numbers in this assay, from the lowest: compound 3; then compounds 2 and 1 (each within the scatter of the next).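

At the aryl group on the amide-type nitrogen, this assay shows a step beyond the scatter, the first one available in this series: a 12-fold lower number from compound 2 to compound 3 (1.09 log units; beyond the scatter) with 4-chlorophenyl in place of 2,6-dimethylphenyl. Both groups count no hydrogen-bond donors or acceptors and no net charge, so those counts do not separate them. Nothing available explains the step.

Whether the step follows the two methyl groups leaving or the chlorine entering stays open, since the compounds shown change both together. Going by these compounds, how an amine or a carboxylic acid on this phenyl ring would read in this assay also stays open.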